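A few compounds are considered here, and "the series" means these few. Any claim that something is new, unique, unknown or untested is made for them only; others in the source may bear on it.

Measured so far:
Compound 1, `[N-]=[N+]=NCC(O)Cn1c(=O)n(C2OC(CO)[C@@H](O)[C@H]2O)c2nc(N)nc(O)c21`; in a functional assay (B cells) with Mus musculus as the target (on this read-out higher numbers stand for an effect only at larger amounts of compound and lower numbers for an effect already at smaller amounts), compound 1 gives 39 uM.
Compound 2, `CN(C)CCCn1c(=O)n(C2OC(CO)[C@@H](O)[C@H]2O)c2nc(N)nc(O)c21`; in this assay compound 2 gives 194 uM.
Compound 3, `Nc1nc(O)c2c(n1)n(C1OC(CO)[C@@H](O)[C@H]1O)c(=O)n2Cc1ccc(OCc2ccccc2)cc1`; in this assay compound 3 gives 8 uM.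

Compound 3 stands lowest of the three numbers in this assay, with compound 1 nearest and compound 2 furthest, and both gaps lie beyond the scatter. Compound 4, `Nc1nc(O)c2c(n1)n(C1OC(CO)[C@@H](O)[C@H]1O)c(=O)n2Cc1ccccc1`, has not yet been measured. It differs from compound 3 in one place: hydrogen in place of benzyloxy on an aromatic carbon. The benzyloxy leaves from the six-membered aromatic ring of carbon only and only a hydrogen enters there. Among the measured compounds shown here, the single measured step, a 5.0-fold higher number from compound 1 to compound 2 (0.70 log units; beyond the scatter), concerns the chain on the aromatic nitrogen and not this ring, so no measured step bears directly on the change. Compound 3 carries the largest group at this place and gives the lowest number, so in this assay compound 4 is expected to give a modestly higher number, estimated at 20 uM with a range from 6 uM to 70 uM. The expected step is a 2.5-fold higher number from compound 3 to compound 4 (0.40 log units; beyond the scatter).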

Compound 4, concentration for half-maximal effect: 6 uM
Beside the measured number, compound 4's estimate is 3.3-fold (0.52 log units) above it; the measured number falls inside the stated range.
By their numbers in this assay, from the lowest: compounds 4 and 3 (each within the scatter of the next); then compound 1; then compound 2.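

In this assay, taking the benzyloxy off the aromatic carbon gives a 1.3-fold lower number from compound 3 to compound 4 (0.12 log units; within the scatter) and so does not separate the two compounds, which shows that the low number of compound 3 does not depend on this group. With the ring left bare, the group on the saturated chain carbon bound to the aromatic nitrogen still matters: phenyl in place of 2-(dimethylamino)ethyl gives a 32-fold lower number from compound 2 to compound 4 (1.51 log units; beyond the scatter) and phenyl in place of 2-azido-1-hydroxyethyl gives a 6.5-fold lower number from compound 1 to compound 4 (0.81 log units; beyond the scatter) as steps beyond the scatter. Nothing available explains these results.

On these data alone, whether a smaller group at that aromatic carbon, such as an amine or a carboxylic acid, would leave the number unmoved remains open. So does the effect of a longer chain carrying the phenyl on the aromatic nitrogen.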